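The compounds below may be only part of what the source reports. "The series", "measured", "known", "first", "only" and "open" are said of these compounds alone.

Measured so far in an assay on isolated protein for inhibition of Rho-associated protein kinase 1 (Homo sapiens), read by scintillation counting, radiometric assay and 33P incorporation, with a stated time of 40 min, in the presence of a further agent that is not named here; on this read-out lower numbers stand for stronger inhibition and higher numbers for weaker inhibition:
compound 1 `CC(=O)Nc1cccc(NC(=O)COc2ccc3c(=O)ccoc3c2)c1` gives 2500 nM;
compound 2 `Cc1cc(C(=O)Nc2cccc(NC(=O)COc3ccc4c(=O)ccoc4c3)c2)ccc1C(F)(F)F` gives 460 nM;
compound 3 `Cc1nc(C(=O)Nc2cccc(NC(=O)COc3ccc4c(=O)ccoc4c3)c2)cs1` gives 473 nM.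

Compound 3 thus holds the second highest of the three numbers. The nearest value belongs to compound 2, and the step of a 1.0-fold higher number from compound 2 to compound 3 (0.01 log units; within the scatter) lies within the scatter. The largest gap among the three is a 5.3-fold lower number from compound 1 to compound 3 (0.72 log units; beyond the scatter). Compound 4 `O=C(COc1ccc2c(=O)ccoc2c1)Nc1cccc(NC(=O)c2cnc(C(F)(F)F)s2)c1` carries 2-(trifluoromethyl)-1,3-thiazol-5-yl in place of 2-methyl-1,3-thiazol-4-yl on a carbonyl carbon. All three measured steps change this same carbonyl carbon: a 5.4-fold lower number from compound 1 to compound 2 (0.74 log units; beyond the scatter) and a 5.3-fold lower number from compound 1 to compound 3 (0.72 log units; beyond the scatter) were modest, whereas swapping one aromatic ring for another, a 1.0-fold higher number from compound 2 to compound 3 (0.01 log units; within the scatter), brought no shift beyond the scatter. Compound 4 keeps an aromatic ring at that carbonyl carbon, so the expected step is a 1.1-fold lower number from compound 3 to compound 4 (0.02 log units; within the scatter), none beyond the scatter. Compound 4 is therefore estimated at 450 nM, between 200 nM and 1000 nM.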

Compound 4, half-maximal inhibitory concentration: 160 nM
Estimate against measurement, compound 4: 2.8-fold (0.45 log units) above, and the stated range ends above it.
By their numbers in this assay, from the lowest: compound 4; then compounds 2 and 3 (each within the scatter of the next); then compound 1.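

Until now, exchanging one aromatic ring for another on this carbonyl carbon had moved nothing beyond the scatter, yet a 3.0-fold lower number from compound 3 to compound 4 (0.47 log units; beyond the scatter) and a 2.9-fold lower number from compound 2 to compound 4 (0.46 log units; beyond the scatter) show that the choice of aromatic group can matter here. Within the data shown here, measured against the methyl of compound 1, the new group gives a 16-fold lower number from compound 1 to compound 4 (1.19 log units; beyond the scatter) and so the only large step in the set. No evidence is available to explain this result.

Compound 4 differs from compound 3 in both the trifluoromethyl group and the point of attachment to the thiazole, so the two changes cannot be separated. On these data alone, a 2-methyl-1,3-thiazol-5-yl group would be needed to divide them, and whether an amine in place of trifluoromethyl would hold the value remains open.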